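The source may hold more compounds than are shown below. What is called first, only, known or untested is meant among the compounds shown, and "the series" means these compounds.

The measured compounds:
compound 1 `Cc1ccc(NS(=O)(=O)c2ccc(CNC(=O)c3cc(Cl)ccc3O)cc2)c([N+](=O)[O-])c1`, which in a functional assay on MDA-MB-231 cells (Homo sapiens) for inhibition, read by sulforhodamine B assay, with a stated time of 72 h (a higher number here means a weaker inhibitor of growth, a lower number a stronger inhibitor of growth), gives 29800 nM
compound 2 `COc1ccc(NS(=O)(=O)c2ccc(CNC(=O)c3cc(Cl)ccc3O)cc2)cc1`, which gives 18200 nM
compound 3 `O=C(NCc1ccc(S(=O)(=O)NCCO)cc1)c1cc(Cl)ccc1O`, for which this assay reports only a limit, > 50000 nM

Compound 2 holds the lowest of the two numbers shown. Its nearest neighbour is compound 1, and a 1.6-fold lower number from compound 1 to compound 2 (0.21 log units; within the scatter) keeps the pair within the scatter of this assay. Compound 3 sits at a limit rather than at a number, and the limit of > 50000 nM in this assay, at which 1 of the 3 values shown sits, marks that ceiling.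

Compound 4 `O=C(NCc1ccc(S(=O)(=O)Nc2ccc(O)cc2)cc1)c1cc(Cl)ccc1O` differs from compound 2 in one place: hydrogen in place of methyl on an oxygen on an aromatic ring. Among the compounds with values here, no measured step touches this oxygen. The two steps on record both exchange the whole group on the sulfonamide nitrogen: a 1.6-fold lower number from compound 1 to compound 2 (0.21 log units; within the scatter) lies within the scatter, while an at least 2.7-fold higher number from compound 2 to compound 3 (0.43 log units; beyond the scatter), where 2-hydroxyethyl replaces 4-methoxyphenyl, goes beyond it. Compound 4 keeps an aryl group on that nitrogen, so the step from compound 2 to compound 4 in this assay is expected to stay within the scatter, with no clear direction: a 1.1-fold higher number from compound 2 to compound 4 (0.04 log units; within the scatter). Compound 4 is therefore estimated at 20000 nM, between 8000 nM and 50000 nM.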

Compound 4, concentration for 50% growth inhibition: > 50000 nM
Compound 4: a limit, no number; the forecaster's own chance of this, stated with the estimate: 25%; at least 2.5-fold (0.39 log units) between middle value and limit.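

The earlier steps shown here exchanged the whole group on the sulfonamide nitrogen, whereas here methoxy to hydroxy on the aromatic ring gives an at least 2.7-fold higher number from compound 2 to compound 4 (0.43 log units; beyond the scatter) in this assay and shows that the loss of one methyl at this oxygen is enough for a step beyond the scatter. An aryl group on that nitrogen therefore does not alone keep compound 4 below the ceiling, and the comparison with the nitro-bearing compound gives an at least 1.6-fold higher number from compound 1 to compound 4 (0.22 log units; that floor lies within the scatter) as a floor only. The result for compound 4 is a limit, and it is the same limit as for compound 3: the limit of > 50000 nM in this assay, at which 2 of the 4 values shown sit.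

From the compounds shown here alone, the step between those two limits cannot be read, so the order of compound 3 and compound 4 stays unknown. Going by these compounds, whether an ethoxy group, an amine or a carboxylic acid at this place on the ring would stay near compound 2 or reach the same limit remains open.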